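Shortening the chain on the aromatic nitrogen

The source may report more compounds than this note shows. Statements on the series, on what has been measured and on what is new or still open speak of the compounds shown alone.

Measured compounds:
compound 1, `CC(C)CCn1c(CN2CCN(C(=O)C3CC3)CC2)nc2ccccc21`: 70%
compound 2, `COc1cccc(Cn2c(CN3CCN(C(=O)C4CC4)CC3)nc3ccccc32)c1`: 44.4%
compound 3, `O=C(C1CC1)N1CCN(Cc2nc3ccccc3n2CC2CCCC2)CC1`: 44.5%

In an assay on isolated protein for inhibition of aldehyde dehydrogenase 1A1 (Homo sapiens), read by spectrophotometry, tested at 10 uM (on this read-out higher numbers stand for more inhibition at the one concentration tested (going by the name of the read-out) and lower numbers for less inhibition), compound 3 gives 44.5%, the second highest of the three numbers. Compound 2 sits right beside it, since a number 0.1 percentage points higher from compound 2 to compound 3 (within the scatter), so no order between these two can be read. Compound 1 stands clearly apart, as a number 25.5 percentage points lower from compound 1 to compound 3 (beyond the scatter) shows.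

Compound 4, `CC(C)Cn1c(CN2CCN(C(=O)C3CC3)CC2)nc2ccccc21`, has not been measured. It differs from compound 3 in one place: isopropyl in place of cyclopentyl on a saturated chain carbon bound to an aromatic nitrogen. Going by the values given here, the step that bears most directly on this change is the one from compound 1 to compound 3, where a number 25.5 percentage points lower from compound 1 to compound 3 (beyond the scatter); read in reverse, taking the cyclopentyl away in favour of a branched open chain was worth a modest gain. Isopropyl is a shorter branched chain than isobutyl, so the gain is expected to be of a similar kind but not necessarily of the full size. The step from compound 1 to compound 2, a number 25.6 percentage points lower from compound 1 to compound 2 (beyond the scatter), only confirms that the isobutyl compound sits highest among those measured.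

For compound 4 in this assay a rise beyond the scatter is therefore expected, a number 15.5 percentage points higher from compound 3 to compound 4 (beyond the scatter), giving an estimated 60% with a range from 42% to 76%.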

Compound 4, a percentage reported as inhibition, at one concentration (the size of the read-out at that concentration, not a potency): 13.1%
Compound 4: the middle estimate sits 46.9 percentage points above what was measured; measured number outside the range, below it.
By their numbers in this assay, from the lowest: compound 4; then compounds 2 and 3 (each within the scatter of the next); then compound 1.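

In this assay, going by these compounds alone, isopropyl in place of isobutyl on a saturated chain carbon bound to an aromatic nitrogen gives a number 56.9 percentage points lower from compound 1 to compound 4 (beyond the scatter), so this position responds far more sharply to the exact group than the earlier compounds showed. The isopropyl group also falls short of the two ring-bearing groups, with a number 31.4 percentage points lower from compound 3 to compound 4 (beyond the scatter) and a number 31.3 percentage points lower from compound 2 to compound 4 (beyond the scatter), so a branched open chain as such does not outdo a ring here: among these compounds, compound 1 stands above the ring-bearing compounds 2 and 3, while compound 4, also branched and open, goes against any such rule. Nothing available here explains why the shorter branched chain ends up so far down.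

The compounds leave open whether isobutyl marks a peak at this position or only one point on a rising trend, which a longer chain such as isopentyl or an unbranched n-butyl chain would help to settle. They also leave open whether a small ring such as cyclopropylmethyl would follow compound 3 or compound 4 in this assay's read-out.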